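From Bromophenyl to Chlorophenyl: Expecting Another Cytotoxicity Limit

The compounds below may be only part of what the source reports. "The series", "measured", "known", "first", "only" and "open" are said of these compounds alone.

Compound 3 `COC(=O)c1cc(-c2cccc(NC(=O)c3ccc(/C=C/C(=O)c4ccc(Br)cc4)cc3)c2)on1` is one of three analogues sharing a common core and differing only in the aryl group on a carbonyl carbon. In an ADME assay on Vero cells (Chlorocebus sabaeus) for cytotoxicity, read by MTT assay, with a stated time of 72 h (on this read-out higher numbers stand for lower toxicity in this test and lower numbers for higher toxicity in this test), compound 3 gives > 20 ug/mL, a limit of the assay rather than a number. Compound 1 `COC(=O)c1cc(-c2cccc(NC(=O)c3ccc(/C=C/C(=O)c4cccc(C(F)(F)F)c4)cc3)c2)on1` likewise reaches only a limit, > 20 ug/mL. Compound 2 `COC(=O)c1cc(-c2cccc(NC(=O)c3ccc(/C=C/C(=O)c4cccc(OC)c4)cc3)c2)on1` also stops at a limit, > 100 ug/mL. The steps a step that the two limits leave unreadable from compound 1 to compound 2, a step that the two limits leave unreadable from compound 1 to compound 3 and a step that the two limits leave unreadable from compound 2 to compound 3 are thus unreadable in size. Compound 4 `COC(=O)c1cc(-c2cccc(NC(=O)c3ccc(/C=C/C(=O)c4ccccc4Cl)cc3)c2)on1` differs from compound 3 by 2-chlorophenyl in place of 4-bromophenyl on a carbonyl carbon. Going by the values given here, no measured step reads on this change, yet given (the limit of > 20 ug/mL in this assay, at which 2 of the 3 values shown sit), compound 4 is expected to sit at a limit too. The step that the limit leaves unreadable from compound 3 to compound 4 is therefore estimated as none beyond the scatter. Compound 4 is expected at 30 ug/mL, ranging from 10 ug/mL to 100 ug/mL.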

Compound 4, half-maximal cytotoxic concentration: > 25 ug/mL
Compound 4 gave a limit, no number; the forecaster's own chance of this, stated with the estimate: 70%; the middle value lies beyond the limit too.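

Compound 4 stops at a limit, as do compound 1, compound 2 and compound 3, so none of the steps from those three to compound 4 can be read. Going by these compounds, the actual values of all four compounds in this assay remain open.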